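This account rests on a few compounds, and the source may have more. Where it says the series, first, only, none or still open, it means among the compounds named here.

Compound 2 `CCN(CC)C(=O)CC1CCc2cc(OC)c(OC)cc21` belongs to a small set of amides built on one shared core. In a functional assay on the whole organism (strain Wistar) for inhibition, with Rattus norvegicus as the target, read by paw edema, with stated times of 60 min and 2 h, at a dose of 100 mg/kg by the oral route (on this read-out lower numbers stand for less inhibition and higher numbers for more inhibition at the one dose given (going by the name of the read-out)), compound 2 gives 40%, which places it second of the three numbers measured. The primary amide compound 1 `COc1cc2c(cc1OC)C(CC(N)=O)CC2` gives 31% in this assay, and the step of a number 9 percentage points higher from compound 1 to compound 2 (within the scatter) lies within the scatter, so the two are not separated. The cyclohexyl amide compound 3 `COc1cc2c(cc1OC)C(CC(=O)NC1CCCCC1)CC2` gives 56% in this assay, and here the step of a number 16 percentage points higher from compound 2 to compound 3 (beyond the scatter) is beyond the scatter, as is a number 25 percentage points higher from compound 1 to compound 3 (beyond the scatter).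

Compound 4 `COc1cc2c(cc1OC)C(CC(=O)NCc1ccccc1)CC2` differs from compound 2 in one place: benzylamino in place of diethylamino on a carbonyl carbon. For the measured compounds named here, the step that bears most directly on this change is the one from compound 2 to compound 3, where a secondary amide carrying a ring replaced the diethylamino group and produced a modest rise. The step from compound 1 to compound 3 points the same way. Going by the values given here, a benzylamino group likewise brings a ring and an amide hydrogen, so a rise of a similar, modest size is expected in this assay, though with only two informative steps the support is thin. Compound 4 is therefore expected to give 52%, within 38% to 66%, an expected step of a number 12 percentage points higher from compound 2 to compound 4 (beyond the scatter).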

Compound 4, a percentage reported as inhibition, in the whole organism at one dose (the size of the read-out at that dose, not a potency): 24%
For compound 4 the middle estimate is 28 percentage points above the measured one; the measured number lies below the stated range.
By their numbers in this assay, from the lowest: compounds 4, 1 and 2 (each within the scatter of the next, the first and the last beyond it); then compound 3.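

In this assay, for the compounds shown here, the earlier compounds left room to read a ring together with an amide hydrogen as enough for a higher number at this carbonyl carbon, but benzyl in place of cyclohexyl on the amide-type nitrogen gives a number 32 percentage points lower from compound 3 to compound 4 (beyond the scatter) in a large step, so the kind of group carried there matters and not simply the presence of a ring. Benzylamino in place of diethylamino gives a number 16 percentage points lower from compound 2 to compound 4 (beyond the scatter) and so runs opposite to the change that led to compound 3, while benzyl in place of hydrogen gives a number 7 percentage points lower from compound 1 to compound 4 (within the scatter) and does not separate the benzyl amide from the primary amide. Going by these compounds alone, compound 3 thus remains the only compound whose steps to all the others lie beyond the scatter, and nothing at hand accounts for the gap between its cyclohexyl and the benzyl of compound 4.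

On these data alone, it remains open whether the high number belongs to cyclohexyl alone or extends to other saturated rings such as cyclopentyl or cycloheptyl on the amide-type nitrogen. Equally open, as far as these compounds go, is whether the low number follows the aromatic ring or its one-carbon link, which a phenyl or a phenethyl group on that nitrogen would address.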